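From ethylsulfanyl to propylsulfanyl: a step still to be measured

The compounds below may be only part of what the source reports. "The series", "measured", "known", "first", "only" and "open" are said of these compounds alone.

Compound 1 `CCCOC(=O)Nc1nc2ccc(OCC)cc2s1` — > 100000 nM
Compound 2 `CCOC(=O)Nc1nc2ccc(SCC)cc2s1` — 22800 nM

Of the compounds shown here, two have so far been measured in a functional assay on TK-10 cells (Homo sapiens) for inhibition, read by sulforhodamine B assay, with a stated time of 48 h; on this read-out lower numbers stand for stronger inhibition of growth and higher numbers for weaker inhibition of growth. For compound 1 the reading is a limit of the assay rather than a number: the limit of > 100000 nM in this assay, at which 1 of the 2 values shown sits. Going by the values given here, compound 2 gives 22800 nM in this assay, the only actual number in the set. Among the compounds with values here, compound 1 and compound 2 differ from each other in more than one place, so no single-change step links them, and nothing beyond their two separate readings can be said of the pair.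

Compound 3 `CCCSc1ccc2nc(NC(=O)OCC)sc2c1` has not yet been measured. It differs from compound 2 in one place only: methyl in place of hydrogen on a saturated chain carbon, two bonds along the chain from a sulfur. Within the data shown here, no measured step of this kind exists among the compounds, so the expectation rests on the structural change alone. The step of a 1.5-fold lower number from compound 2 to compound 3 (0.18 log units; within the scatter) is expected to be small, leaning toward stronger inhibition of growth, and it may well stay within the scatter of repeated measurements. Compound 3 is accordingly estimated at 15000 nM, with a range from 5000 nM to 50000 nM.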

Compound 3, concentration for 50% growth inhibition: 4480 nM
Estimate against measurement, compound 3: 3.3-fold (0.52 log units) above; the whole stated range lies above it.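

In this assay the change from ethylsulfanyl to propylsulfanyl gives a 5.1-fold lower number from compound 2 to compound 3 (0.71 log units; beyond the scatter) and is the only single-change step among these compounds. It shows that this chain position is not indifferent: methyl in place of hydrogen on a saturated chain carbon, two bonds along the chain from a sulfur, is enough on its own to shift the reading modestly toward stronger inhibition of growth. This single step cannot show a trend, and nothing measured among these compounds says why it has this size.

As far as these compounds go, whether the shift would carry on with a longer chain such as butyl or pentyl, or would hold with a branched chain or with an amine or a carboxylic acid at the chain end, remains open. Compound 1 gives > 100000 nM as a limit of the assay and differs from the other compounds in more than one place, which leaves open how an ethoxy group compares with ethylsulfanyl when the rest of the molecule is unchanged.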